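A few compounds are considered here, and "the series" means these few. Any claim that something is new, unique, unknown or untested is made for them only; others in the source may bear on it.

In a functional assay on the whole organism (B cells) with Mus musculus as the target (a higher number here means a larger maximal response, a lower number a smaller maximal response), compound 1 `CCn1c(=O)n(C2OC(CO)[C@@H](O)[C@H]2O)c2nc(N)nc(O)c21` gives 82%, compound 2 `Nc1nc(O)c2c(n1)n(C1OC(CO)[C@@H](O)[C@H]1O)c(=O)n2CC(O)CSc1ccccc1` gives 12%, and compound 3 `Nc1nc(O)c2c(n1)n(C1OC(CO)[C@@H](O)[C@H]1O)c(=O)n2Cc1ccc(Cl)cc1` gives 15%. Compound 3 thus stands second highest of the three numbers, close to compound 2 and far beneath compound 1. Compound 4 `CCCCCCCCCCn1c(=O)n(C2OC(CO)[C@@H](O)[C@H]2O)c2nc(N)nc(O)c21` carries the change (nonyl in place of 4-chlorophenyl on a saturated chain carbon bound to an aromatic nitrogen). Going by the values given here, the steps that bear on this are a number 70 percentage points lower from compound 1 to compound 2 (beyond the scatter), a number 67 percentage points lower from compound 1 to compound 3 (beyond the scatter) and a number 3 percentage points higher from compound 2 to compound 3 (within the scatter): each enlargement of the methyl brought a large fall, and the two larger groups then gave much the same low number. Nonyl is another large group, so only a small step, within the scatter, is expected, estimated as a number 3 percentage points higher from compound 3 to compound 4 (within the scatter). Compound 4 is therefore expected to give about 18%, with a range from 5% to 45%.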

Compound 4, largest response reached (reported as maximal response), in percent of the reference or control that the assay uses: 0%
Compound 4: the middle estimate sits 18 percentage points above what was measured, outside the stated range (below it).
By their numbers in this assay, from the lowest: compound 4; then compounds 2 and 3 (each within the scatter of the next); then compound 1.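

Large groups at this place do not all behave alike in this assay, and the open chain nonyl goes lower still, with a number 15 percentage points lower from compound 3 to compound 4 (beyond the scatter) and a number 12 percentage points lower from compound 2 to compound 4 (beyond the scatter). Set against the small group of compound 1, the fall reaches a number 82 percentage points lower from compound 1 to compound 4 (beyond the scatter). An aromatic ring in the added group is therefore not needed for the loss of response, since nonyl has no ring.

Nothing available explains this fall. On these data alone, whether a short chain such as propyl or butyl would keep part of the response of compound 1 remains open.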